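The source may hold more compounds than are shown below. What is called first, only, known or untested is meant among the compounds shown, and "the series" means these compounds.

Of the compounds shown here, two from a shared series have been measured in a functional assay on HT-29 cells (Homo sapiens) for cytotoxicity, read by MTT assay, with a stated time of 72 h; a lower number here means a stronger inhibitor, a higher number a weaker inhibitor. Compound 1 `COc1cc2c(Oc3ccc(NC(=O)c4cc(-c5ccccc5F)ccn4)cc3F)ccnc2cc1OCCCN1CCCCC1` gives 320 nM in this assay. Compound 2 `COc1cc2c(Oc3ccc(NC(=O)c4nccc(-c5ccc(C)cc5)n4)cc3F)ccnc2cc1OCCCN1CCCCC1` gives 620 nM in this assay, the higher of the two numbers, though its gap to compound 1 lies within the scatter of repeated measurements, so no order between the two can be claimed. Among the measured compounds shown here, the two compounds differ in more than one place, and no single step between them is set out.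

Compound 3 `COc1cc2c(Oc3ccc(NC(=O)c4nccc(-c5ccc(F)cc5F)n4)cc3F)ccnc2cc1OCCCN1CCCCC1` has not yet been measured. It differs from compound 2 in one place: 2,4-difluorophenyl in place of 4-methylphenyl on an aromatic carbon. No measured pair in this set shows the effect of such a swap, so there is no shown step to lean on. Both measured compounds sit close together, and compound 2 gives 620 nM in this assay, so the expectation for compound 3 is a number near that of compound 2, with any step from compound 2 to compound 3 of a 1.2-fold lower number from compound 2 to compound 3 (0.09 log units; within the scatter) expected to stay within the scatter. Compound 3 is therefore estimated at 500 nM in this assay, with a range from 200 nM to 1500 nM.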

Compound 3, half-maximal inhibitory concentration: 400 nM
The estimate for compound 3 lay 1.3-fold (0.10 log units) above the measured number; low and high end bracket the measured number.
By their numbers in this assay, from the lowest: compounds 1, 3 and 2 (each within the scatter of the next).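

Among the compounds shown here, on the aromatic carbon opposite the ring nitrogen, the exchange of 4-methylphenyl for 2,4-difluorophenyl gives the first single-place step in this set: in this assay it amounts to a 1.6-fold lower number from compound 2 to compound 3 (0.19 log units; within the scatter) and so stays within the scatter. At this position, then, the pair gives no ground for telling the two phenyl groups apart, even though one carries a methyl group and the other two fluorine atoms. The earlier compounds shown here could not show this, since they differ in more than one place. Nothing available accounts for the two groups reading alike in this assay.

The pair leaves open how the fluorine atoms contribute individually, since an unsubstituted phenyl ring or a phenyl ring with a single fluorine would be needed to separate them from each other and from the methyl group. It also leaves open whether this position stays as undemanding once the phenyl ring gives way to something of a different kind, such as an amine or a carboxylic acid, where a step beyond the scatter might or might not appear.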